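The source may hold more compounds than are shown below. What is called first, only, known or untested is meant among the compounds shown, and "the series" means these compounds.

Compound 2 `COc1cc(Cl)cc(-c2nn(-c3cccc(NC(=O)Nc4ccc(Cl)c(C(F)(F)F)c4)c3)cc2-c2ccncc2)c1` gives 93% in a functional assay on MDA-MB-435 cells (Homo sapiens) for inhibition, read by sulforhodamine B assay, with a stated time of 48 h, tested at 0.1 uM; on this read-out higher numbers stand for a weaker effect at the one concentration tested and lower numbers for a stronger effect. Among the three measured numbers it stands lowest, though only within the scatter: compound 1 `O=C(Nc1cccc(-n2cc(-c3ccncc3)c(-c3cc(O)cc(Cl)c3)n2)c1)Nc1ccc(Cl)c(C(F)(F)F)c1` gives 94%, and compound 3 `COc1cc(Cl)cc(-c2nn(-c3cccc(NC(=O)Nc4cc(C(F)(F)F)cc(C(F)(F)F)c4)c3)cc2-c2ccncc2)c1` gives 98%. Going by the values given here, the single one-place step, a number 1 percentage points lower from compound 1 to compound 2 (within the scatter), lies within the scatter. Compound 4 `COc1cc(Cl)cc(-c2nn(-c3cccc(NC(=O)c4cccc(C(F)(F)F)c4)c3)cc2-c2ccncc2)c1` differs from compound 2 by 3-(trifluoromethyl)phenyl in place of (4-chloro-3-(trifluoromethyl)phenyl)amino on a carbonyl carbon. Among the compounds with values here, no measured step touches the carbonyl carbon, so none bears directly on this change; the only step available, a number 1 percentage points lower from compound 1 to compound 2 (within the scatter), sits elsewhere in the molecule and was within the scatter. Compound 4 is therefore expected to give 95% in this assay, estimated between 85% and 101%. The step of a number 2 percentage points higher from compound 2 to compound 4 (within the scatter) is thus expected to stay within the scatter.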

Compound 4, a percentage reported as activity, at one concentration (the size of the read-out at that concentration, not a potency): 95%
For compound 4 middle estimate and measured number coincide at the digits printed, within the range that was stated.
By their numbers in this assay, from the lowest: compounds 2, 1, 4 and 3 (each within the scatter of the next).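

The first change shown at this carbonyl carbon, 3-(trifluoromethyl)phenyl in place of (4-chloro-3-(trifluoromethyl)phenyl)amino, gives a number 2 percentage points higher from compound 2 to compound 4 (within the scatter) in this assay. Here the nitrogen with its hydrogen-bond donor and the ring chlorine leave together, and the read-out at the one concentration tested does not separate compound 4 from compound 2. No available evidence bears on this result.

Among the compounds shown, the loss of the nitrogen and the loss of the chlorine stay joined. On these data alone, whether a piperidine or a longer alkyl chain on this carbonyl carbon would read differently remains open.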